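Amide variation on the ketoamide series: phenyl removed

A few compounds are considered here, and "the series" means these few. Any claim that something is new, unique, unknown or untested is made for them only; others in the source may bear on it.

Compound 1, `CN(C)C(=O)C(=O)CCc1ccc(Cl)cc1`, gives > 10000 nM in an assay on HEK-293T cells for inhibition of phospholipase A and acyltransferase 3 (Homo sapiens), with stated times of 30 min and 20 min (a higher number here means a weaker inhibitor, a lower number a stronger inhibitor), which is a limit of the assay and not a number.
Compound 2, `O=C(CCc1ccc(Cl)cc1)C(=O)N1CCOCC1`, gives > 10000 nM in this assay, a limit.
Compound 3, `O=C(CCc1ccc(Cl)cc1)C(=O)N1CC[C@@H](c2ccccc2)C1`, gives > 10000 nM in this assay, a limit.

Compound 3 therefore stands at the limit, like the other two values shown, since (the limit of > 10000 nM in this assay, at which 3 of the 3 values shown sit). Going by the values given here, the one step between measured compounds, a step that the two limits leave unreadable from compound 1 to compound 2, cannot be read because both ends are limits, so no measured step bears on the change considered here. That change leads to compound 4, `O=C(CCc1ccc(Cl)cc1)C(=O)N1CCCC1`, and consists of hydrogen in place of phenyl on a saturated ring carbon. With every measured value at the limit and no readable step, the expectation for compound 4 in this assay is that it remains at the limit as well, giving an estimated step that the limit leaves unreadable from compound 3 to compound 4, none beyond the scatter. Compound 4 is thus expected to show 15000 nM, within a range from 5000 nM to 50000 nM.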

Compound 4, half-maximal inhibitory concentration: > 10000 nM
Compound 4 was reported as a limit; the forecaster's own chance of this, stated with the estimate: 85%; the middle value does not contradict the limit.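

No new step can be read among compound 1, compound 2, compound 3 and compound 4 in this assay, since both ends of every step are limits: the limit of > 10000 nM in this assay, at which 4 of the 4 values shown sit.

The compounds shown leave open whether any amide on the shared core gives a measurable inhibition, and how far these four amides differ.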